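Chloro to Cyano on the Anilide Ring of a Chromone Amide

The source may hold more compounds than are shown below. What is called first, only, known or untested is meant among the compounds shown, and "the series" means these compounds.

Of the compounds shown here, two have been measured in a functional assay on OVCAR-4 cells (Homo sapiens) for inhibition, read by sulforhodamine B assay, tested at 10 uM; on this read-out higher numbers stand for more inhibition at the one concentration tested (going by the name of the read-out) and lower numbers for less inhibition. Compound 1 `COc1cc2oc(-c3cccc(NC(=O)c4ccc([N+](=O)[O-])cc4)c3)cc(=O)c2c(OC)c1OC` gives 57.3% in this assay. Compound 2 `COc1cc2oc(-c3cccc(C(=O)Nc4ccc(Cl)cc4)c3)cc(=O)c2c(O)c1OC` gives 130% in this assay, the higher of the two numbers, and the gap to compound 1 lies beyond the scatter. Among the measured compounds shown here, compound 2 and compound 1 differ in several places at once, so no single step between them can be traced.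

Compound 3 `COc1cc2oc(-c3cccc(C(=O)Nc4ccc(C#N)cc4)c3)cc(=O)c2c(O)c1OC` has not yet been measured. It differs from compound 2 in one place only: cyano in place of chloro on an aromatic carbon.

For the measured compounds named here, no step between measured compounds tells how this change plays out, so the expectation rests on compound 2 alone. Because compound 2 gives 130% in this assay, compound 3 is expected to stay in the same region, with a step of a number 15 percentage points lower from compound 2 to compound 3 (beyond the scatter) that may fall within the scatter or amount to a modest decrease. Compound 3 is estimated at 115% in this assay, with a range from 85% to 140%.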

Compound 3, a percentage reported as inhibition, at one concentration (the size of the read-out at that concentration, not a potency): 88.3%
Estimate against measurement, compound 3: 26.7 percentage points above; low and high end bracket the measured number.
By their numbers in this assay, from the lowest: compound 1; then compound 3; then compound 2.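

In this assay, among the compounds shown here, cyano in place of chloro on the anilide ring gives a number 41.7 percentage points lower from compound 2 to compound 3 (beyond the scatter), the first step that can be traced to a single place, and it shows that this aromatic carbon, para to a large group, is not indifferent to what it carries. The exchange swaps one heavy atom for two and brings in one hydrogen-bond acceptor, with no ring and no net charge involved, and at this place the 4-chlorophenyl amide reads higher than the 4-cyanophenyl amide while the rest of the molecule stays the same. Nothing available explains why the number moves in this direction or by this much.

A single step at a single position cannot show whether the fall reflects the loss of chloro or the arrival of cyano, nor whether a fluorine atom, a bromine atom, a methyl group or a methoxy group at this place would stay close to compound 2 or drop toward compound 3. It also leaves open whether the same exchange would have a similar effect on the core of compound 1, with its reversed amide link.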